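Swapping a Furan for a Pyridine on the Shared Core

The source may hold more compounds than are shown below. What is called first, only, known or untested is meant among the compounds shown, and "the series" means these compounds.

Of the compounds shown here, three have been tested in an ADME assay on HEK293 cells (Homo sapiens) for cytotoxicity, read by CCK-8 assay and cell counting, with a stated time of 2 days; on this read-out higher numbers stand for weaker inhibition and lower numbers for stronger inhibition. Compound 1 `Oc1cccc(-c2cc(-c3ccc(Cl)cc3)nc(-c3ccco3)c2)c1` gives 8190 nM, the highest number of the three. Compound 2 `Oc1cccc(-c2cc(-c3ccco3)nc(-c3ccccc3Cl)c2)c1` gives 1860 nM, and compound 3 `Oc1cccc(-c2cc(-c3cccc(Cl)c3)nc(-c3cccs3)c2)c1` gives 3150 nM. Among the measured compounds shown here, the only single change between measured compounds is the one from compound 1 to compound 2, where a 4.4-fold lower number from compound 1 to compound 2 (0.64 log units; beyond the scatter); compound 3 differs from compound 1 in two places at once, so its value can only be set beside that of compound 1 without a counted step.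

Compound 4 `Oc1cccc(-c2cc(-c3ccc(Cl)cc3)nc(-c3cccnc3)c2)c1` is not yet measured. It differs from compound 1 in one place, (pyridin-3-yl in place of furan-2-yl on an aromatic carbon), with the new group sitting next to the ring nitrogen of the core. For the measured compounds named here, no measured step touches this position or this kind of swap: the step from compound 1 to compound 2 concerns the chlorophenyl group, not the five-membered ring. With nothing to lean on, the expectation is a step in this assay no larger than the scatter, in no set direction, so compound 4 is estimated at 6500 nM, within 2000 nM to 20000 nM, which means an expected step of a 1.3-fold lower number from compound 1 to compound 4 (0.10 log units; within the scatter).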

Compound 4, half-maximal inhibitory concentration: 39500 nM
The estimate for compound 4 lay 6.1-fold (0.78 log units) below the measured number; measured number outside the range, above it.
By their numbers in this assay, from the lowest: compounds 2 and 3 (each within the scatter of the next); then compound 1; then compound 4.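

In this assay, putting pyridin-3-yl in place of furan-2-yl on the shared core gives a 4.8-fold higher number from compound 1 to compound 4 (0.68 log units; beyond the scatter) and so moves the read-out toward weaker inhibition. Among the compounds shown here, this is the first measured step at this position, and it shows that the ring placed next to the ring nitrogen of the core can change the result, not only the chlorophenyl group altered in the earlier step. Nothing in the data explains the shift, and this single pair cannot separate the change in ring size from the change of oxygen to nitrogen.

As far as these compounds go, it remains open whether the same swap would have a similar effect alongside the 2-chlorophenyl group of compound 2. Also open, from the compounds shown here alone, is how a non-aromatic group at this position, such as an amine or a short alkyl chain, would compare.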